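Series notes: from compound 3 to compound 4

The source may hold more compounds than are shown below. What is called first, only, known or untested is meant among the compounds shown, and "the series" means these compounds.

Measured in a functional assay on HCT-116 cells (Homo sapiens) for inhibition, read by CCK-8 assay, with a stated time of 48 h; a higher number here means a weaker inhibitor, a lower number a stronger inhibitor:
- compound 1 `COc1ccc(CN(C(=O)CSC(=S)N2CCCC2)c2cc(OC)c(OC)c(OC)c2)cc1`: 4970 nM
- compound 2 `COc1ccc(CN(C(=O)CSC(=S)N2CCN(C(=O)OC(C)(C)C)CC2)c2ccc(Cl)cc2)cc1`: > 20000 nM, a limit of the assay
- compound 3 `COc1cc(N(Cc2ccc(Cl)cc2)C(=O)CSC(=S)N2CCN(C(=O)OC(C)(C)C)CC2)cc(OC)c1OC`: 8490 nM

Compound 3 stands at 8490 nM, within the scatter of compound 1. Among the measured compounds shown here, no two measured compounds differ in only one place, so the series offers no measured step for scale.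

Compound 4 `COc1ccc(CN(C(=O)CSC(=S)N2CCN(C(=O)OC(C)(C)C)CC2)c2cc(OC)c(OC)c(OC)c2)cc1[N+](=O)[O-]` carries 4-methoxy-3-nitrophenyl in place of 4-chlorophenyl on a saturated chain carbon bound to an amide-type nitrogen.

In this assay, no change beyond the scatter is expected, and the estimated step is a 1.2-fold lower number from compound 3 to compound 4 (0.08 log units; within the scatter). The expected value for compound 4 is 7000 nM, with an estimated range of 2500 nM to 18000 nM.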

Compound 4, half-maximal inhibitory concentration: 980 nM
For compound 4 the middle estimate is 7.1-fold (0.85 log units) above the measured one, and the stated range ends above it.
By their numbers in this assay, from the lowest: compound 4; then compounds 1 and 3 (each within the scatter of the next). At a limit, above all of these: compound 2.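

In this assay, 4-methoxy-3-nitrophenyl in place of 4-chlorophenyl on a saturated chain carbon bound to an amide-type nitrogen gives an 8.7-fold lower number from compound 3 to compound 4 (0.94 log units; beyond the scatter). Among the compounds shown here, this is the first single-place step, and it shows that the group at this position can move the number beyond the scatter while the rest of the compound stays fixed. Nothing measured here accounts for the step.

Still open, on these data alone, is whether the nitro group, the methoxy group or the two together carry the step. Also open, as far as these compounds go, is how an amine or a nitrile would read in place of the nitro group.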